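A few compounds are considered here, and "the series" means these few. Any claim that something is new, unique, unknown or untested is made for them only; others in the source may bear on it.

Working notes on the shared core of compound 1 `Brc1cn2ccnc2c(-c2ccc3ncn(C4CCCCC4)c3c2)n1` in a functional assay on 786-0 cells (Homo sapiens) for inhibition, read by sulforhodamine B assay, with a stated time of 48 h, tested at 10 uM; a lower number here means less inhibition, a higher number more inhibition at the concentration tested (going by the name of the read-out). Compound 1 gives 10%. Compound 2 `Fc1ccc(-c2cn3ccnc3c(-c3ccc4ncn(C5CCCCC5)c4c3)n2)cc1`, carrying 4-fluorophenyl in place of bromo on an aromatic carbon, gives 11.2%; the step of a number 1.2 percentage points higher from compound 1 to compound 2 (within the scatter) leaves the pair within the scatter of each other, so compound 2 stands level with compound 1 on the numbers shown. Compound 3 `Fc1ccccc1-c1cn2ccnc2c(-c2ccc3ncn(C4CCCCC4)c3c2)n1` differs from compound 2 only thus: 2-fluorophenyl in place of 4-fluorophenyl on an aromatic carbon. Among the measured compounds shown here, no measured step exchanges one fluorophenyl for another; the sole step known moved nothing beyond the scatter. For compound 3 the expected step is a number 0.2 percentage points lower from compound 2 to compound 3 (within the scatter), none beyond the scatter. Compound 3 is estimated at 11%, between 0% and 25%.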

Compound 3, a percentage reported as inhibition, at one concentration (the size of the read-out at that concentration, not a potency): 2.94%
Estimate against measurement, compound 3: 8.1 percentage points above; measured number inside the range.
By their numbers in this assay, from the lowest: compounds 3, 1 and 2 (each within the scatter of the next).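

In this assay, 2-fluorophenyl in place of 4-fluorophenyl gives a number 8.3 percentage points lower from compound 2 to compound 3 (within the scatter), so on this aromatic carbon next to the ring nitrogen, the two fluorophenyl isomers cannot be told apart. With 2-fluorophenyl in place of bromo, the result is a number 7.1 percentage points lower from compound 1 to compound 3 (within the scatter), which leaves bromo and both fluorophenyl groups level. No measured evidence bears on these numbers. Open, as far as these compounds go, is whether any group on this carbon can move inhibition beyond the scatter. An amine or a carboxylic acid here would be a direct test, as the groups shown are only bromo and fluorophenyl.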